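Sulfonamide diamines: pancreatic cell growth inhibition notes

This account rests on a few compounds, and the source may have more. Where it says the series, first, only, none or still open, it means among the compounds named here.

Measured in a functional assay on BXPC-3 cells (Homo sapiens) for inhibition, read by MTT assay, with a stated time of 72 h; a higher number here means a weaker inhibitor of growth, a lower number a stronger inhibitor of growth:
compound 1 `O=S(=O)(NCCCNCc1ccc(Cl)c(C(F)(F)F)c1)c1cc(C(F)(F)F)cc(C(F)(F)F)c1`: 7800 nM
compound 2 `CN(CCCNS(=O)(=O)c1cc(C(F)(F)F)cc(C(F)(F)F)c1)Cc1ccccc1`: 39000 nM

Compound 2 stands at the highest of the two numbers; compound 1 sits lower by a margin beyond the usual scatter. Compound 3 `COc1ccc(CNCCCNS(=O)(=O)c2cc(C(F)(F)F)cc(C(F)(F)F)c2)cc1` is not yet measured in this assay. It carries (4-methoxybenzyl)amino in place of benzyl(methyl)amino on a saturated chain carbon, three bonds along the chain from a sulfonamide nitrogen. Compound 1, the other secondary amine in the set, gives 7800 nM, whereas compound 3 carries a different aryl substituent, so only a partial move toward that number is expected. The expected step is a 2.6-fold lower number from compound 2 to compound 3 (0.41 log units; beyond the scatter), a lowering beyond the scatter. For compound 3 the estimate is 15000 nM, range 5000 nM to 45000 nM.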

Compound 3, concentration for 50% growth inhibition: 1300 nM
The estimate for compound 3 lay 12-fold (1.06 log units) above the measured number; the whole stated range lies above it.
By their numbers in this assay, from the lowest: compound 3; then compound 1; then compound 2.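

In this assay, (4-methoxybenzyl)amino in place of benzyl(methyl)amino gives a 30-fold lower number from compound 2 to compound 3 (1.48 log units; beyond the scatter), so a change at this saturated chain carbon can shift growth inhibition strongly. Between the two secondary amines, 4-methoxyphenyl in place of 4-chloro-3-(trifluoromethyl)phenyl gives a 6.0-fold lower number from compound 1 to compound 3 (0.78 log units; beyond the scatter), so the aryl substitution alone also moves the number. No supporting data bear on the reason for either step.

The step to compound 3 combines loss of the methyl with gain of the methoxy, leaving their separate contributions unresolved. As far as these compounds go, how an unsubstituted benzylamino group or a longer chain would read remains open.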